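The source may report more compounds than this note shows. Statements on the series, on what has been measured and on what is new or still open speak of the compounds shown alone.

The study rests on three measured compounds and one still to be measured in a functional assay on HeLa cells (Homo sapiens) for inhibition, read by MTT assay; on this read-out lower numbers stand for stronger inhibition and higher numbers for weaker inhibition. Compound 1 `CCCCCCCCn1cc(/C=C/C(=O)c2ccc(NC(=O)CN3CCN(c4ccccc4F)CC3)cc2)nn1` gives 33800 nM in this assay, the highest number of the three. Compound 3 `CC(C)(C)OC(=O)N1CCN(CC(=O)Nc2ccc(C(=O)/C=C/c3cn(Cc4ccc(Br)cc4)nn3)cc2)CC1` gives 18900 nM in this assay, and the gap between compound 1 and compound 3 lies within the usual scatter of such measurements. Compound 2 `O=C(CBr)Nc1ccc(C(=O)/C=C/c2cn(Cc3ccc(Br)cc3)nn2)cc1` gives 7950 nM in this assay, a lower number than compound 1 by a gap beyond the scatter. Among the measured compounds shown here, no single-point step between any two of these measured compounds is available, so what the three values show is all that can be said of them.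

The unmeasured compound 4 `CCCCCCCCn1cc(/C=C/C(=O)c2ccc(NC(=O)CN3CCN(c4ccccc4OC)CC3)cc2)nn1` differs from compound 1 in one place: methoxy in place of fluoro on an aromatic carbon. This is a small exchange at the outer end of the molecule, far from the part of the structure that compounds 2 and 3 vary. For the measured compounds named here, with no measured step of this kind to lean on, the expectation is that the step from compound 1 to compound 4 stays close to none beyond the scatter, expected as a 1.1-fold lower number from compound 1 to compound 4 (0.05 log units; within the scatter). Compound 4 is therefore estimated at 30000 nM in this assay, with a range from 12000 nM to 80000 nM.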

Compound 4, half-maximal inhibitory concentration: 26800 nM
Estimate against measurement, compound 4: 1.1-fold (0.05 log units) above; measured number inside the range.
By their numbers in this assay, from the lowest: compound 2; then compounds 3, 4 and 1 (each within the scatter of the next).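

In this assay, among the compounds shown here, replacing 2-fluorophenyl with 2-methoxyphenyl gives a 1.3-fold lower number from compound 1 to compound 4 (0.10 log units; within the scatter), the first single-place comparison in this set and one that does not separate the two groups at this position on an aromatic carbon, ortho to a large group. The earlier compounds shown here could not show this, as no two of them differed in only one place, whereas here the rest of the molecule is held constant while methoxy, with one more heavy atom than fluoro and a hydrogen-bond acceptor that fluoro lacks, takes its place without a step beyond the scatter. No measurement at hand accounts for this reading or ties either group to a particular property.

As far as these compounds go, whether an amine, a carboxylic acid or a hydroxyl group on that same aromatic carbon would also stay within the scatter of compound 1 remains open, so a single step cannot define how much change this position admits. Also open, from the compounds shown here alone, is whether the exchange of fluoro for methoxy would read the same with a longer chain in place of the octyl group.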